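The source may hold more compounds than are shown below. What is called first, only, known or untested is meant among the compounds shown, and "the series" means these compounds.

Three compounds have been measured in a functional assay on MCF7 cells (Homo sapiens) for antiproliferative activity, read by MTT assay, with a stated time of 48 h, tested at 50 uM; a lower number here means a stronger effect, a higher number a weaker effect of the compound at the concentration tested:

compound 1 `OC(CCn1nc2c(Br)c(Br)c(Br)c(Br)c2n1)c1cccc(Br)c1`, 11%
compound 2 `COc1cccc(C(O)CCn2nc3c(Br)c(Br)c(Br)c(Br)c3n2)c1`, 20%
compound 3 `C[C@@H](O)CCn1nc2c(Br)c(Br)c(Br)c(Br)c2n1`, 64%

Compound 3 gives the highest number of the three and thus the weakest effect; compound 2 lies nearest to it and compound 1 furthest, both gaps beyond the scatter. Compound 4 `CC(O)CCn1nc2c(Br)c(Br)c(Br)c(Br)c2n1` differs from compound 3 in one point only: the two compounds have the same atoms and bonds; at least one stereo element is drawn with a configuration in one of them and without one in the other: 1 of 1 stereo elements differ; a stereocentre at a saturated chain carbon is drawn R in compound 3 and without a configuration in compound 4. Within the data shown here, the single measured step, a number 9 percentage points higher from compound 1 to compound 2 (within the scatter), concerns a group on an aromatic ring and says nothing about a stereocentre, so no precedent exists for this change. Compound 4 is therefore expected to stay close to the value of compound 3. The expected step is a number 4 percentage points lower from compound 3 to compound 4 (within the scatter), within the scatter. The estimate for compound 4 is 60%, between 42% and 78%.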

Compound 4, a percentage reported as activity, at one concentration (the size of the read-out at that concentration, not a potency): 76%
Compound 4: the middle estimate sits 16 percentage points below what was measured; low and high end bracket the measured number.
By their numbers in this assay, from the lowest: compounds 1 and 2 (each within the scatter of the next); then compound 3; then compound 4.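

In this assay, the change at this saturated chain carbon gives a number 12 percentage points higher from compound 3 to compound 4 (beyond the scatter), a modest shift towards a weaker effect, and the only difference between the two structures is this: the fact that one of compounds 3 and 4 is drawn with a defined configuration and the other without, at the place where they differ

The other changes at this carbon are far larger, with methyl in place of 3-methoxyphenyl giving a number 56 percentage points higher from compound 2 to compound 4 (beyond the scatter) and methyl in place of 3-bromophenyl giving a number 65 percentage points higher from compound 1 to compound 4 (beyond the scatter), so the group held here matters much more than how the stereocentre is drawn.

Going by these compounds, what the opposite drawn configuration would give remains open, as does the effect of a cyclohexyl group or an amine in place of the methyl.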